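The source may hold more compounds than are shown below. What is called first, only, known or untested is meant among the compounds shown, and "the series" means these compounds.

Compound 2 `COc1ccc(N(C(=O)CN2C=CN(c3ccccc3)C(=O)[C@H](Cc3n[nH]c4ccccc34)C2=O)C(C)C)cc1` is one of three compounds sharing a core in which a phenyl-bearing ring carries an indazolylmethyl side chain and an acetamide arm. In a functional assay on CHO cells for agonist activity at Melanocortin receptor 4 (Homo sapiens), read by a luciferase reporter, with a stated time of 4 h (on this read-out lower numbers stand for an effect already at smaller amounts and higher numbers for an effect only at larger amounts of compound), compound 2 gives 339 nM, the highest of the three numbers. Compound 1 `CC(C)N(C(=O)CN1C=CN(c2ccccc2)C(=O)C(Cc2n[nH]c3ccccc23)C1=O)c1ccc(OC(F)(F)F)cc1` differs in the aryl group on the amide nitrogen and gives 151 nM; compound 3 `O=C1[C@@H](Cc2n[nH]c3ccccc23)C(=O)N(c2ccccc2)C=CN1CC(=O)N1CCCCc2ccccc21` carries a fused bicyclic amine in place of the anilide and gives 100 nM. Among the measured compounds shown here, the only single-place step among the measured compounds is a 3.4-fold lower number from compound 2 to compound 3 (0.53 log units; beyond the scatter), which concerns the amide substituent and not the stereocentre.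

Compound 4 `COc1ccc(N(C(=O)CN2C=CN(c3ccccc3)C(=O)C(Cc3n[nH]c4ccccc34)C2=O)C(C)C)cc1` is the next compound. Its difference from compound 2 is the two compounds have the same atoms and bonds; at least one stereo element is drawn with a configuration in one of them and without one in the other: 1 of 1 stereo elements differ; a stereocentre at a saturated ring carbon is drawn R in compound 2 and without a configuration in compound 4. For the measured compounds named here, no measured step bears on this change: compound 1 is also drawn without a configuration at that centre, but it differs from compound 2 in the aryl group as well, so its values show no isolated effect of stereochemistry. Because compound 2 gives 339 nM and no stereochemical comparison exists, compound 4 is expected to fall close to compound 2, with a step of a 1.3-fold higher number from compound 2 to compound 4 (0.12 log units; within the scatter) that stays within the scatter or rises slightly. The estimate for compound 4 in this assay is 450 nM, between 180 nM and 1100 nM.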

Compound 4, half-maximal effective concentration: 708 nM
Beside the measured number, compound 4's estimate is 1.6-fold (0.20 log units) below it, and the stated range covers the measured number.
By their numbers in this assay, from the lowest: compounds 3 and 1 (each within the scatter of the next); then compound 2; then compound 4.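

The stereocentre now has its first isolated comparison in this assay: a 2.1-fold higher number from compound 2 to compound 4 (0.32 log units; beyond the scatter). That step is beyond the scatter, although only modest, and nothing else separates the pair, so it can be tied only to how this one centre is drawn: the fact that one of compounds 2 and 4 is drawn with a defined configuration and the other without, at the place where they differ. Among the compounds shown here, compound 1 and compound 4 are both drawn without a configuration at that centre, which also gives the first clean reading of the group on the oxygen, a 4.7-fold higher number from compound 1 to compound 4 (0.67 log units; beyond the scatter), with methyl in place of trifluoromethyl and the number rising on that change.

The compounds shown leave open how a compound drawn with the opposite configuration at the stereocentre would read, and whether the gap between the drawn and undrawn forms would hold with trifluoromethyl on the oxygen. They also leave open whether ethyl or difluoromethyl on that oxygen would give a number nearer to that of compound 1 or to that of compound 4.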